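This account rests on a few compounds, and the source may have more. Where it says the series, first, only, none or still open, it means among the compounds named here.

Compound 1 `Cc1cccc(NNC(=O)c2ccc(NS(=O)(=O)c3cnc(O)nc3O)cc2)c1` and compound 2 `Cc1ccccc1NNC(=O)c1cccc(NS(=O)(=O)c2cnc(O)nc2O)c1` share a core and are compared side by side. In a functional assay on MDA-MB-231 cells (Homo sapiens) for antiproliferative activity, read by MTT assay, with a stated time of 24 h (a higher number here means a weaker inhibitor, a lower number a stronger inhibitor), compound 1 gives only a limit, > 20000 nM. In this assay compound 2 likewise gives only a limit, > 20000 nM. Compound 2 thus sits where compound 1 sits: the limit of > 20000 nM in this assay, at which 2 of the 2 values shown sit. Compound 3 `O=C(NNC(=O)c1cccc(NS(=O)(=O)c2cnc(O)nc2O)c1)c1cccc(Cl)c1` differs from compound 2 in one place: (3-chlorophenyl)carbonyl in place of 2-methylphenyl on an amine nitrogen. Within the data shown here, no step between measured compounds exists to size this change, and both known values are limits. Compound 3 is expected to give 20000 nM in this assay, between 5000 nM and 60000 nM. The expected step, a number no higher from compound 2 to compound 3 (the limit leaves the size open), is none beyond the scatter, most likely another limit.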

Compound 3, half-maximal inhibitory concentration: 3180 nM
For compound 3 the middle estimate is 6.3-fold (0.80 log units) above the measured one; the whole stated range lies above it.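

On the amine nitrogen, (3-chlorophenyl)carbonyl in place of 2-methylphenyl gives an at least 6.2-fold lower number from compound 2 to compound 3 (0.79 log units; beyond the scatter) in this assay, showing that a change at this position can bring a measurable antiproliferative effect. The value of compound 2 is a limit, and the step therefore has a floor but no known size. Only compound 3 gives a measured number, and the other compounds remain at a limit: the limit of > 20000 nM in this assay, at which 2 of the 3 values shown sit.

The carbonyl and the chlorine enter together, and the compounds shown do not separate their contributions. Going by these compounds, how an unsubstituted benzoyl or an acetyl group would read at this nitrogen remains open.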